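The source may report more compounds than this note shows. Statements on the series, on what has been measured and on what is new or still open speak of the compounds shown alone.

Compound 1 `CCOC(=O)c1cnc(NN2C(=O)C=C(C)C2=O)nc1-c1cc2ccccc2s1`: 800 nM
Compound 2 `CCOC(=O)c1cnc(N(C)N2C(=O)C=C(C)C2=O)nc1C(F)(F)C(F)(F)F`: 350 nM; 450 nM (2 entries)
Compound 3 `CCOC(=O)c1cnc(N(C)N2C(=O)C=C(C)C2=O)nc1CC`: 35 nM

In a functional assay on Jurkat cells (Homo sapiens) for inhibition (a lower number here means a stronger inhibitor, a higher number a weaker inhibitor), compound 3 gives 35 nM, the lowest of the two single numbers. Compound 1 gives 800 nM in this assay, a gap beyond the scatter. For compound 2 the several entries the several entries of compound 2 in this assay, 350 nM; 450 nM (2 entries) form a spread rather than one number. Compound 4 `CCOC(=O)c1cnc(N(C)N2C(=O)C=C(C)C2=O)nc1-c1cc2ccccc2s1` has not been measured. It differs from compound 3 by 1-benzothiophen-2-yl in place of ethyl on an aromatic carbon. Among the compounds with values here, no measured pair isolates this change; compound 1, which also carries 1-benzothiophen-2-yl, gives 800 nM, so a move toward a higher number is expected. Compound 4 is estimated at 300 nM, between 80 nM and 1500 nM. The expected step is an 8.6-fold higher number from compound 3 to compound 4 (0.93 log units; beyond the scatter).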

Compound 4, half-maximal inhibitory concentration: 130 nM
Estimate against measurement, compound 4: 2.3-fold (0.36 log units) above; the measured number falls inside the stated range.
By their numbers in this assay, from the lowest: compound 3; then compound 4; then compound 1.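

At this aromatic carbon next to the ring nitrogen, 1-benzothiophen-2-yl in place of ethyl gives a 3.7-fold higher number from compound 3 to compound 4 (0.57 log units; beyond the scatter) in this assay, so the position accepts 1-benzothiophen-2-yl at a modest cost. Compound 4 also isolates the nitrogen on the aromatic ring: with 1-benzothiophen-2-yl held constant, methyl in place of hydrogen gives a 6.2-fold lower number from compound 1 to compound 4 (0.79 log units; beyond the scatter) in this assay. Nothing available here accounts for either step. Open, on these data alone, is how an amine, a carboxylic acid or a longer chain would read at this aromatic carbon. Also open, as far as these compounds go, is whether the methyl step holds with ethyl there.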